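Swapping chloro for cyano on an insoluble scaffold

The source may hold more compounds than are shown below. What is called first, only, known or untested is meant among the compounds shown, and "the series" means these compounds.

Three compounds have been measured in a physicochemical assay for solubility, using the shake flask method, in simulated intestinal fluid, measured as kinetic solubility, with a stated time of 2 h, at 25 degrees C, at pH 6.5; a higher number here means a more soluble compound, a lower number a less soluble compound:

Compound 1 `COC(=O)c1nc(C)c2c(c1N)C(=O)N(Cc1ccccc1)C2=O` gives 7400 nM.
Compound 2 `Cc1nc(C(=O)OC2CC2)c(N)c2c1C(=O)N(Cc1ccccc1)C2=O` gives 202000 nM.
Compound 3 `Cc1noc(-c2nc(C)c3c(c2N)C(=O)N(Cc2ccc(Cl)cc2)C3=O)n1` gives only a limit of the assay, < 5000 nM.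

Within the data shown here, only one pair differs in a single place: a 27-fold higher number from compound 1 to compound 2 (1.44 log units; beyond the scatter). That step concerns the ester side of the shared core and says nothing about the benzyl side, which is where the change of interest sits.

Compound 3 stands apart from the other two. Its value is not a number but a limit, as noted in the limit of < 5000 nM in this assay, at which 1 of the 3 values shown sits, so its true solubility is known only to lie at the low end of this small set.

Compound 4 `Cc1noc(-c2nc(C)c3c(c2N)C(=O)N(Cc2ccc(C#N)cc2)C3=O)n1` differs from compound 3 in a single way: cyano in place of chloro on an aromatic carbon. Put another way, 4-chlorobenzyl becomes 4-cyanobenzyl.

Among the measured compounds shown here, no measured step bears on this change; the only step on record alters the ester and is unrelated. With nothing to lean on, the expectation for the step that the limit leaves unreadable from compound 3 to compound 4 is no change beyond the scatter. The estimate for compound 4 in this assay is therefore 4000 nM, within a range of 1000 nM to 15000 nM, with a substantial chance that only a limit is reported again.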

Compound 4, solubility: < 5000 nM
Compound 4: a limit, no number; the forecaster's own chance of this, stated with the estimate: 60%; the middle value is on the limit's open side.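

In this assay compound 4 gives < 5000 nM, which is a limit of the assay and not a number. Among these compounds, compound 3 sits at the same limit, so no step from compound 3 to compound 4 can be read: the limit of < 5000 nM in this assay, at which 2 of the 4 values shown sit. The compounds shown leave open how the true solubilities of compound 3 and compound 4 compare, and whether cyano in place of chloro changes anything.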